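The source may report more compounds than this note shows. Statements on the series, on what has been measured and on what is new or still open speak of the compounds shown alone.

Going by the values given here, compound 3, `O=c1cc(CCO)c2ccc(OCc3cccc(Cl)c3)cc2o1`, gives 7.41 nM in an assay on brain (strain Sprague-Dawley) for inhibition of Amine oxidase [flavin-containing] B (Rattus norvegicus), read by spectrophotometry (on this read-out lower numbers stand for stronger inhibition and higher numbers for weaker inhibition), and stands lowest of the three numbers measured so far. Compound 1, `CCNC(=O)Nc1cc(=O)oc2cc(OCc3cccc(Cl)c3)ccc12`, gives 31600 nM, and compound 2, `O=C(O)COc1cc(=O)oc2cc(OCc3cccc(Cl)c3)ccc12`, gives 31600 nM; the step of no change at the digits printed from compound 1 to compound 2 (within the scatter) lies within the scatter, while a 4300-fold lower number from compound 1 to compound 3 (3.63 log units; beyond the scatter) and a 4300-fold lower number from compound 2 to compound 3 (3.63 log units; beyond the scatter) are both large. Compound 4, `O=c1cc(CCBr)c2ccc(OCc3cccc(Cl)c3)cc2o1`, carries bromo in place of hydroxy on a saturated chain carbon, two bonds along the chain from an aromatic carbon. Among the compounds with values here, no measured step touches this position of the 2-hydroxyethyl chain: the two large steps ending at compound 3 exchange the whole group on the aromatic carbon, not the hydroxy at the end of the chain, so they show only that this part of the core is sensitive to what sits there, not how a change of hydroxy to bromo acts. Without a direct precedent, the author expects compound 4 to remain close to compound 3, with a 1.6-fold higher number from compound 3 to compound 4 (0.21 log units; within the scatter) held within or only slightly beyond the scatter, and estimates 12 nM for compound 4, with a range of 2.5 nM to 60 nM.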

Compound 4, half-maximal inhibitory concentration: 32.4 nM
The estimate for compound 4 lay 2.7-fold (0.43 log units) below the measured number; measured number inside the range.
By their numbers in this assay, from the lowest: compound 3; then compound 4; then compounds 1 and 2 (each within the scatter of the next).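

In this assay, going by these compounds alone, the exchange of hydroxy for bromo on a saturated chain carbon, two bonds along the chain from an aromatic carbon, gives a 4.4-fold higher number from compound 3 to compound 4 (0.64 log units; beyond the scatter) and is the first step to read this change directly: it is modest, yet beyond the scatter. The hydroxy is therefore not needed for a low number, although compound 3 stays lower than compound 4. With 2-bromoethyl on the aromatic carbon the steps of a 980-fold lower number from compound 2 to compound 4 (2.99 log units; beyond the scatter) and a 980-fold lower number from compound 1 to compound 4 (2.99 log units; beyond the scatter) remain large, and nothing shown bears on the cause of any of these steps.

From the compounds shown here alone, whether an amine, a methoxy or a fluoro at this chain carbon would fall nearer compound 3 or compound 4 remains open. So does the effect of a longer chain carrying the same hydroxy or bromo.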